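A few compounds are considered here, and "the series" means these few. Any claim that something is new, unique, unknown or untested is made for them only; others in the source may bear on it.

Measured compounds, both values limits rather than numbers:
- Compound 1 `Cc1noc(-c2nc(C)c3c(c2N)C(=O)N(Cc2ccc(F)cc2)C3=O)n1` gives < 5000 nM (a limit)
- Compound 2 `COc1ccccc1CN1C(=O)c2c(C)nc(-c3nc(C)no3)c(N)c2C1=O` gives < 5000 nM (a limit)

In a physicochemical assay for solubility, using the shake flask method, in simulated intestinal fluid, measured as kinetic solubility, with a stated time of 2 h, at 25 degrees C, at pH 6.5 (on this read-out lower numbers stand for lower solubility and higher numbers for higher solubility), compound 2 stands at < 5000 nM as a limit, not a number. As the limit of < 5000 nM in this assay, at which 2 of the 2 values shown sit, shows, neither measured compound has a readable number. Compound 3 `Cc1noc(-c2nc(C)c3c(c2N)C(=O)N(Cc2ccc(Cl)cn2)C3=O)n1` carries 5-chloropyridin-2-yl in place of 2-methoxyphenyl on a saturated chain carbon bound to an amide-type nitrogen in a ring. For the measured compounds named here, the one measured step at this place (a step that the two limits leave unreadable from compound 1 to compound 2) has no readable size, so no step beyond the usual scatter is expected in this assay here. The expected change is a step that the limit leaves unreadable from compound 2 to compound 3 as estimated from this. Compound 3 is expected at 2500 nM (estimated range 800 nM to 5000 nM).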

Compound 3, solubility: < 5000 nM
Compound 3 ended at the assay's limit; the forecaster's own chance of this, stated with the estimate: 85%; the middle value is on the limit's open side.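

For the compounds shown here, compound 1, compound 2 and compound 3 all give a limit rather than a number, so no step between them can be read: the limit of < 5000 nM in this assay, at which 3 of the 3 values shown sit. The compounds shown leave open their actual solubility values and whether exchanging these groups changes them.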